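Amino Acid Ester in Place of a Free Hydroxy Group

A few compounds are considered here, and "the series" means these few. Any claim that something is new, unique, unknown or untested is made for them only; others in the source may bear on it.

Compound 1, `CC(C)(CO)COC1(c2ccc(Cl)cc2)c2ccccc2C(=O)N1Cc1ccccc1`, gives 71000 nM in a functional assay on HCT-116 cells (Homo sapiens) for inhibition, read by fluorescence, with a stated time of 48 h; a higher number here means a weaker inhibitor of growth, a lower number a stronger inhibitor of growth. Compound 2, `CC(C)[C@H](N)C(=O)OCCCOC1(c2ccc(Cl)cc2)c2ccccc2C(=O)N1Cc1ccccc1`, gives 20000 nM in this assay. Compound 3, `O=C1c2ccccc2C(OCCCO)(c2ccc(Cl)cc2)N1Cc1ccccc1`, gives 79000 nM in this assay.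

Compound 3 has the highest of the three numbers; compound 1 lies within the scatter of it, while a 4.0-fold higher number from compound 2 to compound 3 (0.60 log units; beyond the scatter). Compound 4, `N[C@H](C(=O)OCCCOC1(c2ccc(Cl)cc2)c2ccccc2C(=O)N1Cc1ccccc1)c1ccccc1`, differs from compound 3 in one place: (amino(phenyl)methyl)carbonyl in place of hydrogen on an oxygen on a saturated carbon. The step that bears on this is the reverse of a 4.0-fold higher number from compound 2 to compound 3 (0.60 log units; beyond the scatter), where an amino acid ester replaced hydrogen on the same oxygen; a 3.6-fold lower number from compound 1 to compound 2 (0.55 log units; beyond the scatter) points the same way. A lowering of similar size in this assay is therefore expected for compound 4, namely a 3.6-fold lower number from compound 3 to compound 4 (0.56 log units; beyond the scatter). Compound 4 is estimated at 22000 nM, in the range 8000 nM to 60000 nM.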

Compound 4, concentration for 50% growth inhibition: 14000 nM
Beside the measured number, compound 4's estimate is 1.6-fold (0.20 log units) above it; low and high end bracket the measured number.
By their numbers in this assay, from the lowest: compounds 4 and 2 (each within the scatter of the next); then compounds 1 and 3 (each within the scatter of the next).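

In this assay, a second amino acid ester on this oxygen also lowers the number: placing (amino(phenyl)methyl)carbonyl on the hydroxy group gives the step (a 5.6-fold lower number from compound 3 to compound 4 (0.75 log units; beyond the scatter)). Phenyl in place of isopropyl on the saturated chain carbon bound to an amine nitrogen and a carbonyl carbon does not separate the two esters (a 1.4-fold lower number from compound 2 to compound 4 (0.15 log units; within the scatter)). Nothing available explains either step. The compounds shown leave open whether the amine is needed, or whether an ester alone, such as an acetyl ester on the same oxygen, would give a similar lowering.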